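The compounds below may be only part of what the source reports. "The series", "measured", "known", "first", "only" and "open" are said of these compounds alone.

Working notes on the series. Compound 2 `O=C(NCCC1CCN(Cc2ccccc2)CC1)c1coc2ccccc2c1=O` and compound 1 `COc1ccc2occ(C(=O)NC3CCN(Cc4ccccc4)CC3)c(=O)c2c1` share a common core and the same benzyl-bearing end, but differ both in the chain that joins the amide to the ring and in the substitution of the core. In an assay on isolated protein for inhibition of Amine oxidase [flavin-containing] B (Homo sapiens), read by fluorescence and Amplex Red, with stated times of 15 min and 20 min (on this read-out higher numbers stand for weaker inhibition and lower numbers for stronger inhibition), compound 2 gives 35300 nM. In this assay compound 1 gives 46300 nM. Among the measured compounds shown here, compound 2 holds the lowest of the two numbers, but the gap to compound 1 falls within the scatter, so no order between them can be read, and since the two differ in more than one place no single step is isolated from them.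

Compound 3 `O=C(NCCC1CCN(Cc2ccccc2)CC1)c1coc2ccc(Br)cc2c1=O` differs from compound 2 by bromo in place of hydrogen on an aromatic carbon. For the measured compounds named here, no measured pair shows this change, so the expectation rests on compound 2 alone. A step from compound 2 to compound 3 of a 2.9-fold lower number from compound 2 to compound 3 (0.47 log units; beyond the scatter) toward stronger inhibition is expected, held loosely. For compound 3 in this assay the estimated value is 12000 nM, with a range from 3000 nM to 40000 nM.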

Compound 3, half-maximal inhibitory concentration: 26100 nM
Beside the measured number, compound 3's estimate is 2.2-fold (0.34 log units) below it, within the range that was stated.
By their numbers in this assay, from the lowest: compounds 3, 2 and 1 (each within the scatter of the next).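

In this assay, among the compounds shown here, bromo in place of hydrogen on an aromatic carbon, meta to a fused ring and para to a fused ring, gives a 1.4-fold lower number from compound 2 to compound 3 (0.13 log units; within the scatter), and this is the first step that isolates a change in one place. At this position, the entry of one bromine atom therefore leaves compound 2 and compound 3 indistinguishable on this read-out, and the pair gives no sign that this change alone separates the two compounds. No independent data bear on the interpretation of this result.

On these data alone, whether a different group on the same aromatic carbon, such as an amine, a carboxylic acid or a fluoro group, would give a step beyond the scatter remains open, as does whether the same holds for bromo on the other aromatic carbons of the shared core. As far as these compounds go, the separate contributions of the chain joining the amide to the ring and of the core substitution also remain unresolved, since compound 1 and compound 2 differ in both places, and a longer chain on the bromo-bearing core is an equally open question.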